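The source may report more compounds than this note shows. Statements on the series, on what has been measured and on what is new or still open speak of the compounds shown alone.

Going by the values given here, compound 1 `Cn1c(Cc2nn(C)c(=O)c3ccccc23)nnc1SCCCCCCCC(=O)Nc1ccc(Cl)cc1Cl` is the one member of the series with a number in an assay on 32D cells for inhibition of interleukin-15 (Mus musculus), read by resazurin assay, with stated times of 30 min and 2.5 days, in the presence of a further agent that is not named here (a higher number here means a weaker inhibitor, a lower number a stronger inhibitor), where compound 1 gives 2200 nM. Compound 2 `Cn1nc(Cc2nnc(SCC(=O)Nc3ccc(Cl)cc3Cl)n2CCC(=O)O)c2ccccc2c1=O` reaches only a limit of the assay, giving > 30000 nM, which is the limit of > 30000 nM in this assay, at which 1 of the 2 values shown sits. Compound 3 `Cn1nc(Cc2nnc(SCCCCCCCC(=O)Nc3ccc(Cl)cc3Cl)n2CCCO)c2ccccc2c1=O` differs from compound 1 by 2-hydroxyethyl in place of hydrogen on a saturated chain carbon bound to an aromatic nitrogen, the long chain and the dichloroanilide being kept. Among the compounds with values here, no measured pair shows this change, so the step expected from compound 1 to compound 3, no change at the digits printed from compound 1 to compound 3 (within the scatter), is estimated to stay within the usual scatter, in no set direction. For compound 3 the expected value is 2200 nM, with a range from 700 nM to 7000 nM.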

Compound 3, half-maximal inhibitory concentration: > 30000 nM
Compound 3 ended at the assay's limit; the forecaster's own chance of this, stated with the estimate: 10%; middle value at least 13-fold (1.13 log units) from the limit.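

In this assay, the position on a saturated chain carbon bound to an aromatic nitrogen proves sensitive: with the long chain and the dichloroanilide kept, 2-hydroxyethyl in place of hydrogen gives an at least 13-fold higher number from compound 1 to compound 3 (1.13 log units; beyond the scatter). Compound 3 gives > 30000 nM, which is a limit of the assay and not a number. Compound 1 remains the only member of the series with a number: the limit of > 30000 nM in this assay, at which 2 of the 3 values shown sit.

As far as these compounds go, whether the loss follows the added chain or its hydroxyl stays open, and a plain propyl chain at this position would separate the two. From the compounds shown here alone, an amine or a carboxylic acid on the same chain, with the long chain kept, is also open.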